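The source may report more compounds than this note shows. Statements on the series, on what has been measured and on what is new or still open speak of the compounds shown alone.

In a functional assay on CEM13 cells (Homo sapiens) for cytotoxicity, read by MTT assay, with a stated time of 72 h (a higher number here means a weaker inhibitor, a lower number a stronger inhibitor), three compounds have been measured so far:

compound 1 `Cc1c(C)c2c(c(C)c1O)CCC(C)(C(=O)NC1CC(C)(C)N([O])C(C)(C)C1)O2`: > 300000 nM, a limit of the assay
compound 2 `Cc1c(C)c2c(c(C)c1OC(=O)CCC(=O)O)CCC(C)(C(=O)NC1CC(C)(C)N([O])C(C)(C)C1)O2`: > 300000 nM, a limit of the assay
compound 3 `Cc1c(C)c2c(c(C)c1OC(=O)CCC(=O)O)CCC(C)(C(=O)NC1CC(C)(C)N([O])C1(C)C)O2`: 205000 nM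

Compound 2 therefore stands at the limit of > 300000 nM in this assay, at which 2 of the 3 values shown sit; its value is a limit, not a number. Compound 4 `Cc1c(C)c2c(c(C)c1OC(=O)CCC(=O)NC1CC(C)(C)N([O])C(C)(C)C1)CCC(C)(C(=O)NC1CC(C)(C)N([O])C(C)(C)C1)O2` differs from compound 2 by a group of 12 heavy atoms (9 carbon, 2 nitrogen, 1 oxygen; one six-membered non-aromatic ring with 1 hetero atom) in place of one oxygen atom, on a carbonyl carbon. Of the measured steps, a step that the two limits leave unreadable from compound 1 to compound 2 cannot be read from the two limits, and an at least 1.4-fold lower number from compound 2 to compound 3 (0.16 log units; that floor lies within the scatter) concerns a different part of the molecule. Neither step touches the carbonyl carbon where compound 4 changes, so no guide to direction exists, and no step beyond the scatter is expected. Compound 4 is estimated at 250000 nM, between 100000 nM and 600000 nM, which is expected to mean an at least 1.2-fold lower number from compound 2 to compound 4 (0.07 log units; that floor lies within the scatter) in this assay.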

Compound 4, half-maximal inhibitory concentration: > 300000 nM
Compound 4 ended at the assay's limit; the forecaster's own chance of this, stated with the estimate: 60%; middle value at least 1.2-fold (0.07 log units) away from the limit.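

Compound 2 and compound 4 each carry only a limit of the assay, not a number, so no step between them can be read: the limit of > 300000 nM in this assay, at which 3 of the 4 values shown sit.

On these data alone, what replacing the hydroxy on the carbonyl carbon with this group of 12 heavy atoms does in this assay stays open.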